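Swapping a Benzyl for an Iodophenyl on a Piperazine

The compounds below may be only part of what the source reports. "The series", "measured", "known", "first", "only" and "open" are said of these compounds alone.

Of the compounds shown here, three sharing one core have been measured in an assay on CHO cells for displacement of a labelled ligand from adenosine receptor A1 (Homo sapiens), read by scintillation counting, with a stated time of 90 min, in the presence of a further agent that is not named here; a higher number here means a weaker inhibitor, a lower number a stronger inhibitor. Compound 1 `CCCn1c(=O)[nH]c2nc(-c3ccc(S(=O)(=O)N(C)C)cc3)[nH]c2c1=O` carries a small dimethyl sulfonamide and gives 190 nM. Compound 2 `CCCn1c(=O)[nH]c2nc(-c3ccc(S(=O)(=O)N4CCN(Cc5cccc(Br)c5)CC4)cc3)[nH]c2c1=O` carries a piperazine sulfonamide bearing a 3-bromobenzyl group and gives 928 nM, the highest of the two numbers, with compound 1 as its nearest neighbour at a distance beyond the usual scatter. Compound 3 `CCCn1c(=O)[nH]c2nc(-c3ccc(S(=O)(=O)N4CCN(c5ccccc5)C(C)C4)cc3)[nH]c2c1=O`, whose piperazine carries a phenyl group and a methyl, reaches only the limit of > 1000 nM in this assay, so no number is known for it; (the limit of > 1000 nM in this assay, at which 1 of the 3 values shown sits).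

Compound 4 `CCCn1c(=O)[nH]c2nc(-c3ccc(S(=O)(=O)N4CCN(c5ccc(I)cc5)CC4)cc3)[nH]c2c1=O` has not yet been measured. It differs from compound 2 in one place: 4-iodophenyl in place of 3-bromobenzyl on an amine nitrogen in a ring. Among the compounds with values here, no pair of measured compounds differs in exactly this way, so there is no directly measured step to lean on. What the values show is that compound 3, the other compound with an aryl group directly on the piperazine nitrogen, sits at the limit, while compound 2 sits somewhat beneath it. On that basis the change is expected to weaken binding modestly, with a fair chance that only a limit is reported; the step of a 1.7-fold higher number from compound 2 to compound 4 (0.24 log units; within the scatter) is the expected size. Compound 4 is estimated at 1600 nM, within a range from 500 nM to 5000 nM.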

Compound 4, inhibition constant: > 1000 nM
Compound 4: no number, only a limit; the forecaster's own chance of this, stated with the estimate: 55%; the middle value does not contradict the limit.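

In this assay compound 4 gives only a limit, > 1000 nM, so no number is known for it. The step is therefore a floor, an at least 1.0-fold higher number from compound 2 to compound 4 (0.03 log units; that floor lies within the scatter), and it shows that 4-iodophenyl in place of 3-bromobenzyl on this piperazine nitrogen brings no clear gain in binding, while any loss cannot be sized, since the floor cannot separate a real loss from ordinary scatter. Both compounds shown with an aryl ring directly on the piperazine nitrogen, compound 3 and compound 4, now end without a number: the limit of > 1000 nM in this assay, at which 2 of the 4 values shown sit.

This one change alters three things at once: the halogen, its place on the ring and the carbon link between the ring and the nitrogen, so the compounds shown cannot say which of these matters. A 4-iodobenzyl group or a 3-bromophenyl group on the same nitrogen would pull these apart, and a simple unsubstituted benzyl group would show what the halogen contributes at all.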